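This account rests on a few compounds, and the source may have more. Where it says the series, first, only, none or still open, it means among the compounds named here.

Compound 1 `Cn1c(=O)c2[nH]c(Cc3ccco3)nc2n(Cc2ccco2)c1=O` is measured in an assay on HEK293 cells for displacement of a labelled ligand from adenosine receptor A2b (Homo sapiens) (on this read-out lower numbers stand for stronger inhibition and higher numbers for weaker inhibition), at 316 nM. Compound 2 `CCn1c(=O)c2[nH]c(Cc3ccco3)nc2n(Cc2ccco2)c1=O` differs from it by one change, (methyl in place of hydrogen on a saturated chain carbon bound to an aromatic nitrogen), and in this assay compound 2 gives 126 nM; the step is a 2.5-fold lower number from compound 1 to compound 2 (0.40 log units; beyond the scatter). Compound 3 `CCn1c(=O)c2c(nc(Cc3ccccc3)n2C)n(Cc2ccco2)c1=O` is built on a different core, and the difference between the two cores is not broken down here. In this assay compound 3 gives 12.9 nM, the lowest of the three numbers. Compound 4 `CCCn1c(=O)c2c(nc(Cc3ccccc3)n2C)n(Cc2ccco2)c1=O` is not yet measured; it differs from compound 3 by methyl in place of hydrogen on a saturated chain carbon, two bonds along the chain from an aromatic nitrogen, the same kind of change as before, though at a different place, since here the carbon is two bonds along the chain from an aromatic nitrogen rather than bound to it. Among the measured compounds shown here, the step expected for compound 4 is a 1.6-fold lower number from compound 3 to compound 4 (0.21 log units; within the scatter), judged smaller than the earlier one because a 2.5-fold lower number from compound 1 to compound 2 (0.40 log units; beyond the scatter) sits at a different place and is the only guide. Compound 4 is estimated to give 8 nM in this assay, between 3 nM and 30 nM.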

Compound 4, inhibition constant: 43.7 nM
Estimate against measurement, compound 4: 5.5-fold (0.74 log units) below, and the stated range ends below it.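

Lengthening the ethyl chain to propyl gives a 3.4-fold higher number from compound 3 to compound 4 (0.53 log units; beyond the scatter). Set beside the earlier step, the direction reverses, so the gain from one added methyl in this assay did not carry over to the other core: the same change on two cores in this assay, a 2.5-fold lower number (0.40 log units; beyond the scatter) from compound 1 to compound 2 and a 3.4-fold higher number (0.53 log units; beyond the scatter) from compound 3 to compound 4, 8.5-fold (0.93 log units) apart, beyond the scatter of two such steps

This does not show that the core alone decides the outcome: the methyl also sits at a different place, two bonds along the chain from an aromatic nitrogen rather than on a carbon bound to it, and a single pair on each core cannot separate the two.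

The compounds shown leave open how a propyl chain reads on the core of compound 1. They also leave open how a longer chain such as butyl, or an amine in its place, reads on either core.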